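Solubility notes: replacing dimethylamino in compound 2

This account rests on a few compounds, and the source may have more. Where it says the series, first, only, none or still open, it means among the compounds named here.

Measured in a physicochemical assay for solubility, measured as kinetic solubility; a lower number here means a less soluble compound, a higher number a more soluble compound:
Compound 1 `Cc1cc(-c2noc([C@H](C)NC(=O)c3cc(C(F)(F)F)nn3C)n2)ccn1`: 179000 nM
Compound 2 `C[C@H](NC(=O)c1cc(C(F)(F)F)nn1C)c1nc(-c2ccnc(N(C)C)c2)no1`: 28000 nM

Compound 2 holds the lower of the two numbers. Compound 3 `COC(C)(C)c1cc(-c2noc([C@H](C)NC(=O)c3cc(C(F)(F)F)nn3C)n2)ccn1` is not yet measured. Compared with compound 2, it carries 1-methoxy-1-methylethyl in place of dimethylamino on an aromatic carbon. Among the compounds with values here, one measured step bears on this: a 6.4-fold lower number from compound 1 to compound 2 (0.81 log units; beyond the scatter), modest, with dimethylamino entering at the same aromatic carbon. Within the data shown here, no measurement yet covers 1-methoxy-1-methylethyl, so the direction is weakly held. The expected step in this assay is a 1.6-fold higher number from compound 2 to compound 3 (0.21 log units; within the scatter), with nothing beyond the scatter anticipated. The estimated value for compound 3 is 45000 nM, with an expected range of 15000 nM to 130000 nM.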

Compound 3, solubility: 123000 nM
Beside the measured number, compound 3's estimate is 2.7-fold (0.44 log units) below it; measured number inside the range.
By their numbers in this assay, from the lowest: compound 2; then compounds 3 and 1 (each within the scatter of the next).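

At this aromatic carbon, next to the ring nitrogen, the step of a 4.4-fold higher number from compound 2 to compound 3 (0.64 log units; beyond the scatter) in this assay shows that the lower number does not persist once dimethylamino is replaced by 1-methoxy-1-methylethyl. Against methyl, the step of a 1.5-fold lower number from compound 1 to compound 3 (0.16 log units; within the scatter) stays within the scatter, so among these compounds only compound 2, with dimethylamino, stands apart. No data here account for the difference between these groups. Open, on these data alone, is whether a primary amine or a methoxy group at this carbon would fall with compound 2 or with compounds 1 and 3.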